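Trifluoromethyl to methyl, second aryl position

The source may report more compounds than this note shows. Statements on the series, on what has been measured and on what is new or still open speak of the compounds shown alone.

Compound 1 `NC(=O)c1c(NC(=O)c2ccc(C(F)(F)F)cc2)sc2c1CCN(Cc1c(Cl)cccc1Cl)C2` gives 8530 nM in a functional assay on MKN-74 cells (Homo sapiens) for antiproliferative activity, with a stated time of 24 h; a higher number here means a weaker inhibitor, a lower number a stronger inhibitor. Compound 2 `Cc1ccc(C(=O)Nc2sc3c(c2C(N)=O)CCN(Cc2c(Cl)cccc2Cl)C3)cc1` gives 12300 nM in this assay; the change methyl in place of trifluoromethyl on an aromatic carbon made a step of a 1.4-fold higher number from compound 1 to compound 2 (0.16 log units; within the scatter). Compound 3 `NC(=O)c1c(NC(=O)c2ccccc2Cl)sc2c1CCN(C(=S)Nc1ccccc1C(F)(F)F)C2` gives 1870 nM in this assay, the lowest of the three numbers. The difference between the cores of compound 3 and compound 1 is not broken down here. Compound 4 `Cc1ccccc1NC(=S)N1CCc2c(sc(NC(=O)c3ccccc3Cl)c2C(N)=O)C1` is not yet measured in this assay and differs from compound 3 by methyl in place of trifluoromethyl on an aromatic carbon. The surroundings differ: in compound 1 the group sits para to a large group, in compound 3 ortho to a large group, so this is the same kind of change, not the same. From compound 3 to compound 4 a step of a 1.3-fold higher number from compound 3 to compound 4 (0.11 log units; within the scatter) is expected, resting on the small step from compound 1 to compound 2, a 1.4-fold higher number from compound 1 to compound 2 (0.16 log units; within the scatter). Compound 4 is therefore estimated at 2400 nM, between 1000 nM and 6000 nM.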

Compound 4, half-maximal inhibitory concentration: 11700 nM
Compound 4: middle estimate off by 4.9-fold (0.69 log units), on the low side, and the stated range ends below it.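

In this assay the change gives a clear loss on the second core, a step of a 6.3-fold higher number from compound 3 to compound 4 (0.80 log units; beyond the scatter). Set beside the earlier step, its size does not carry from one core to the other: the same change on two cores in this assay, a 1.4-fold higher number (0.16 log units; within the scatter) from compound 1 to compound 2 and a 6.3-fold higher number (0.80 log units; beyond the scatter) from compound 3 to compound 4, 4.3-fold (0.64 log units) apart, beyond the scatter of two such steps

So a small step on the core of compound 1 gives no safe forecast for the core of compound 3, but with one pair per core this is no general rule, and the data do not say which difference between the cores sets the gap.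

Open, as far as these compounds go, is where a methoxy, a nitrile or a plain hydrogen in place of the trifluoromethyl would fall on each core. Also open, from the compounds shown here alone, is whether the step on the core of compound 3 is specific to methyl.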